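A few compounds are considered here, and "the series" means these few. Any claim that something is new, unique, unknown or untested is made for them only; others in the source may bear on it.

In a functional assay with Rattus norvegicus as the target (on this read-out lower numbers stand for stronger inhibition and higher numbers for weaker inhibition), compound 1 (`COc1ccc2[nH]c(=O)c(=O)oc2c1`) gives 28000 nM, while compound 2 (`O=c1[nH]c2cc([N+](=O)[O-])ccc2oc1=O`) gives 800 nM. Compound 1 therefore holds the higher of the two numbers, meaning the weaker inhibition, and the gap between them lies beyond the usual scatter. Compound 3 (`N#Cc1ccc2[nH]c(=O)c(=O)oc2c1`) has not yet been measured. It keeps the core of compound 1 but carries cyano in place of methoxy on an aromatic carbon. Within the data shown here, the two measured compounds differ in more than one place, so no measured step isolates a single change, and any forecast rests on thin evidence. The only guide is compound 2, whose value of 800 nM shows that a far lower number is reachable among these close relatives. A move toward lower numbers, of moderate size and beyond the scatter, is expected in this assay, and the estimated step is a 9.3-fold lower number from compound 1 to compound 3 (0.97 log units; beyond the scatter). The expected value for compound 3 is 3000 nM, with an estimated range from 500 nM to 15000 nM.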

Compound 3, half-maximal inhibitory concentration: 15000 nM
Compound 3: middle estimate off by 5.0-fold (0.70 log units), on the low side, within the range that was stated.
By their numbers in this assay, from the lowest: compound 2; then compounds 3 and 1 (each within the scatter of the next).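

In this assay, among these compounds, the exchange of methoxy for cyano on this aromatic carbon gives a 1.9-fold lower number from compound 1 to compound 3 (0.27 log units; within the scatter), and this is the first step in the set that isolates a change in a single place. It shows that, at this carbon, para to a fused ring and meta to a fused ring, these two groups cannot be told apart on this read-out, so the exchange by itself gives no measurable separation between compound 1 and compound 3. Nothing measured here offers an explanation for this result.

Among the compounds shown here, it remains open whether a different group on the same aromatic carbon, such as an amine, a carboxylic acid or a longer alkoxy chain, would move the number beyond the scatter, since methoxy and cyano are the only two groups compared there. Compound 2, at 800 nM, is joined to neither compound 1 nor compound 3 by a single-place step, and what sets its value remains unresolved.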